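Chloro in place of bromo: a small halogen swap

A few compounds are considered here, and "the series" means these few. Any claim that something is new, unique, unknown or untested is made for them only; others in the source may bear on it.

Of the compounds shown here, three sharing one core have been tested in an assay for inhibition of Indoleamine 2,3-dioxygenase 1 (Homo sapiens), read by spectrophotometry, with stated times of 1 h and 4 h; on this read-out lower numbers stand for stronger inhibition and higher numbers for weaker inhibition. Compound 1 `CC(=O)Nc1ccc(S(=O)(=O)NNc2ccc(Cl)cc2)cc1` gives 155 nM. Compound 2 `CC(=O)Nc1ccc(S(=O)(=O)NNc2ccc(Br)cc2)cc1` gives 130 nM. Compound 3 `CC(=O)Nc1ccc(S(=O)(=O)NNc2ccc(F)c(Br)c2)cc1` gives 128 nM. Compounds 2 and 1 differ in a single spot, (chloro in place of bromo on an aromatic carbon), and that change produced a 1.2-fold higher number from compound 2 to compound 1 (0.08 log units; within the scatter). How the core of compound 3 differs from that of compound 2 is not broken down here; their two values show only that they sit very close together.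

Compound 4 `CC(=O)Nc1ccc(S(=O)(=O)NNc2ccc(F)c(Cl)c2)cc1` has not yet been measured. It differs from compound 3 by chloro in place of bromo on an aromatic carbon. This is the same kind of change as the earlier one, though not the same: earlier the place was para to a large group, whereas here it is ortho to a fluoro group and meta to a large group. Because the earlier swap gave only a 1.2-fold higher number from compound 2 to compound 1 (0.08 log units; within the scatter), the expected step is a 1.2-fold higher number from compound 3 to compound 4 (0.07 log units; within the scatter), a small one that stays inside ordinary scatter. Compound 4 is therefore estimated at 150 nM, most likely falling between 75 nM and 300 nM.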

Compound 4, half-maximal inhibitory concentration: 110 nM
Compound 4: the middle estimate sits 1.4-fold (0.13 log units) above what was measured; the range from low to high includes it.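

On the core of compound 3, chloro in place of bromo on an aromatic carbon gives a 1.2-fold lower number from compound 3 to compound 4 (0.07 log units; within the scatter) in this assay. Set beside the same swap on the other core, the two steps cannot be told apart: the same change on two cores in this assay, a 1.2-fold higher number (0.08 log units; within the scatter) from compound 2 to compound 1 and a 1.2-fold lower number (0.07 log units; within the scatter) from compound 3 to compound 4, 1.4-fold (0.14 log units) apart, within the scatter of two such steps

So on these two cores the swap leaves the number within ordinary scatter, and the opposite directions of the two small steps carry no meaning of their own; what this does not show is that chloro and bromo would behave alike on other cores or at other places, since two pairs are a narrow base for any general rule.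

The compounds shown carry only halogens on the ring at the hydrazine end, and all of them keep the same acetamide at the other end. Going by these compounds, whether an amine, a carboxylic acid or a methoxy group on that ring, or a longer chain in place of the acetamide, would move the number beyond the scatter stays open.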